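Swapping the aryl group on a pyrazole acid: two measured points

The source may report more compounds than this note shows. Statements on the series, on what has been measured and on what is new or still open speak of the compounds shown alone.

Compounds measured in a functional assay on BJAB cells (Homo sapiens) for antiproliferative activity, with a stated time of 4 days; on this read-out lower numbers stand for an effect already at smaller amounts and higher numbers for an effect only at larger amounts of compound:
- compound 1 `Cc1cc(C)cc(-c2c(C)nn(-c3nc(-c4ccc(Cl)c(Cl)c4)c(SC(C)C)s3)c2C(=O)O)c1`, which gives 2700 nM
- compound 2 `CNc1cc(-c2c(C)nn(-c3nc(-c4ccc(Cl)c(Cl)c4)c(SC(C)C)s3)c2C(=O)O)ccn1`, which gives 18000 nM

Compound 2 holds the highest of the two numbers; its nearest neighbour is compound 1, and the step of a 6.7-fold higher number from compound 1 to compound 2 (0.82 log units; beyond the scatter) lies beyond the scatter. The unmeasured compound 3 `Cc1nn(-c2nc(-c3ccc(Cl)c(Cl)c3)c(SC(C)C)s2)c(C(=O)O)c1-c1cc(C#N)cc(C(F)(F)F)c1` is reached from compound 2 by the change (3-cyano-5-(trifluoromethyl)phenyl in place of 2-(methylamino)pyridin-4-yl on an aromatic carbon).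

Among the compounds with values here, only one measured step touches this site, the step of a 6.7-fold higher number from compound 1 to compound 2 (0.82 log units; beyond the scatter), in which the carbon-only 3,5-dimethylphenyl ring was replaced by 2-(methylamino)pyridin-4-yl and the number rose. Compound 3 returns to a six-membered aromatic ring of carbon only, now carrying a nitrile and a trifluoromethyl group, so the move from compound 2 to compound 3 is expected to run the other way, with a step of about a 5.1-fold lower number from compound 2 to compound 3 (0.71 log units; beyond the scatter). Because the nearest carbon-only precedent is compound 1 at 2700 nM, compound 3 is estimated at 3500 nM, within a range from 1200 nM to 11000 nM.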

Compound 3, half-maximal effective concentration: 3600 nM
Beside the measured number, compound 3's estimate is 1.0-fold (0.01 log units) below it; low and high end bracket the measured number.
By their numbers in this assay, from the lowest: compounds 1 and 3 (each within the scatter of the next); then compound 2.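

In this assay, the 3-cyano-5-(trifluoromethyl)phenyl group gives a 5.0-fold lower number from compound 2 to compound 3 (0.70 log units; beyond the scatter), so the high number of compound 2 is not shared by this second carbon-only ring. The two carbon-only rings, although they carry quite different substituents, show a 1.3-fold higher number from compound 1 to compound 3 (0.12 log units; within the scatter), which leaves compound 1 and compound 3 indistinguishable on this read-out, and among these three compounds only the 2-(methylamino)pyridin-4-yl group stands apart, with no compound going against that picture. No measurement bearing on why this position responds in this way is available, so the result describes the numbers and gives no explanation for them.

The compounds shown leave open whether the step belongs to the ring nitrogen or to the methylamino group, a question that an unsubstituted pyridin-4-yl ring and a phenyl ring carrying a methylamino group would separate. They also leave open whether the same ranking of these aryl groups would hold with an amide in place of the carboxylic acid on the shared core.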